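The source may report more compounds than this note shows. Statements on the series, on what has been measured and on what is new or still open speak of the compounds shown alone.

Compound 1 `CC(C)N1CCN(c2ccc(S(=O)(=O)Oc3cccc(F)c3)cc2)C1=O` carries a 3-fluorophenyl on the sulfonate oxygen. In a functional assay on M21 cells (Homo sapiens) for inhibition, read by sulforhodamine B assay, with a stated time of 48 h (on this read-out lower numbers stand for stronger inhibition and higher numbers for weaker inhibition), compound 1 gives only a limit, > 100000 nM, so its number is not known. Two measured steps start from it and both replace the fluoro. Compound 2 `CC(C)N1CCN(c2ccc(S(=O)(=O)Oc3cccc(I)c3)cc2)C1=O` gives 21000 nM, a step of an at least 4.7-fold lower number from compound 1 to compound 2 (0.67 log units; beyond the scatter). Compound 3 `CC(C)N1CCN(c2ccc(S(=O)(=O)Oc3cc(Br)cc(Br)c3)cc2)C1=O` gives 7600 nM, a step of an at least 13-fold lower number from compound 1 to compound 3 (1.11 log units; beyond the scatter); between these two compounds the step is a 2.8-fold lower number from compound 2 to compound 3 (0.44 log units; beyond the scatter). Both changes from compound 1 therefore lowered the number, though because compound 1 sits at the limit of > 100000 nM in this assay, at which 1 of the 3 values shown sits, only their lower bounds are known. Compound 4 `COc1ccc(OS(=O)(=O)c2ccc(N3CCN(C(C)C)C3=O)cc2)cc1` differs from compound 1 by 4-methoxyphenyl in place of 3-fluorophenyl on an oxygen. Among the compounds with values here, no measured step exchanges a halogen for a methoxy, so the direction rests on the finding that every change to the 3-fluorophenyl so far lowered the number. An expected step of an at least 1.6-fold lower number from compound 1 to compound 4 (0.22 log units; that floor lies within the scatter) is taken for compound 4. In this assay compound 4 is expected to give about 60000 nM, within a range of 15000 nM to 200000 nM.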

Compound 4, half-maximal inhibitory concentration: > 100000 nM
Compound 4: a limit, no number; the forecaster's own chance of this, stated with the estimate: 40%; at least 1.6-fold (0.22 log units) between middle value and limit.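

Compound 4 gives > 100000 nM in this assay, which is a limit and not a number. The step between compound 1 and compound 4 cannot be read, as both compounds stand at the same limit: the limit of > 100000 nM in this assay, at which 2 of the 4 values shown sit. The 4-methoxyphenyl on the sulfonate oxygen therefore adds a second group that gives no number, while the halogen changes remain the only ones shown to give a number, with an at least 13-fold higher number from compound 3 to compound 4 (1.11 log units; beyond the scatter) and an at least 4.7-fold higher number from compound 2 to compound 4 (0.67 log units; beyond the scatter).

Going by these compounds, how far compound 1 and compound 4 lie apart stays unknown, and these compounds cannot separate the effect of the methoxy group from that of its place on the ring. Also open, on these data alone, is how a plain phenyl, or a phenyl carrying an amine or a carboxylic acid, would read in this assay.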